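Swapping the ring sulfur for oxygen in a melanocortin ligand

The source may hold more compounds than are shown below. What is called first, only, known or untested is meant among the compounds shown, and "the series" means these compounds.

Three compounds share one core and differ only in the oxidation state of a ring sulfur. Compound 1 `CC(C)C[C@H](N)c1cc(C(F)(F)F)ccc1N1CCN(C(=O)[C@H]2CSC[C@@H]2c2ccc(Cl)cc2)CC1` carries a plain sulfide; in an assay on HEK293 cells for displacement of a labelled ligand from Melanocortin receptor 4 (Homo sapiens) (a lower number here means a stronger inhibitor, a higher number a weaker inhibitor), compound 1 gives 280 nM. Compound 2 `CC(C)C[C@H](N)c1cc(C(F)(F)F)ccc1N1CCN(C(=O)[C@H]2C[S+]([O-])C[C@@H]2c2ccc(Cl)cc2)CC1` carries the sulfoxide and gives 120 nM in this assay. Compound 3 `CC(C)C[C@H](N)c1cc(C(F)(F)F)ccc1N1CCN(C(=O)[C@H]2CS(=O)(=O)C[C@@H]2c2ccc(Cl)cc2)CC1` carries the sulfone and gives 38 nM. Compound 1 thus stands at the highest number of the three, meaning the weakest binding: its nearest neighbour is compound 2, already beyond the usual scatter, and compound 3 lies furthest from it.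

Compound 4 `CC(C)C[C@H](N)c1cc(C(F)(F)F)ccc1N1CCN(C(=O)C2COCC2c2ccc(Cl)cc2)CC1` takes a different route from compound 1: 4-(4-chlorophenyl)oxolan-3-yl in place of 4-(4-chlorophenyl)thiolan-3-yl on a carbonyl carbon. The sulfur leaves the five-membered ring altogether and an oxygen takes its place, so the count of hydrogen-bond acceptors stays at one on each side. Going by the values given here, no measured pair in this set shows the effect of exactly this exchange, so there is no directly comparable step to lean on.

The expectation is that the step of a 1.1-fold lower number from compound 1 to compound 4 (0.05 log units; within the scatter) stays small, at most a modest move in either direction and quite possibly within the scatter of repeated measurements. Compound 4 is therefore estimated at 250 nM in this assay, with a range from 80 nM to 800 nM.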

Compound 4, inhibition constant: 280 nM
For compound 4 the middle estimate is 1.1-fold (0.05 log units) below the measured one; low and high end bracket the measured number.
By their numbers in this assay, from the lowest: compound 3; then compound 2; then compounds 1 and 4 (each within the scatter of the next).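

Replacing 4-(4-chlorophenyl)thiolan-3-yl with 4-(4-chlorophenyl)oxolan-3-yl on a carbonyl carbon brings no change at the digits printed from compound 1 to compound 4 (within the scatter) in this assay so at this position a ring oxygen can stand in for the plain ring sulfur without any visible effect on binding. The earlier compounds shown here kept sulfur in the ring and varied only its oxidation state, so they could not show whether the number depends on sulfur itself; this step shows that, at least for the unoxidised ring, swapping sulfur for oxygen leaves the reading where it was. No measurement offered here explains why the two rings read alike.

The entering group is drawn without defined stereocentres while the leaving group has 2, so it remains unclear whether separate stereoisomers of compound 4 would give different numbers. As far as these compounds go, it also remains open how a ring nitrogen bearing a methyl group, or a plain cyclopentane ring carrying the same 4-chlorophenyl group, would compare with the sulfone of compound 3 at 38 nM in this assay and with the oxygen ring of compound 4.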